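This account rests on a few compounds, and the source may have more. Where it says the series, first, only, none or still open, it means among the compounds named here.

Compound 3 `CSc1nc2ccccc2n1C1CCN(CCCC(c2ccc(F)cc2)c2ccc(F)cc2)CC1` stands at the lowest number among the three compounds measured in a functional assay on the whole organism (strain STD-ddY) for inhibition, with Mus musculus as the target, with a stated time of 5 min (on this read-out higher numbers stand for an effect only at larger amounts of compound and lower numbers for an effect already at smaller amounts), where compound 3 gives 13 mg/kg. Compound 2 `Fc1ccc(C(CCCN2CCC(n3c(=S)[nH]c4ccccc43)CC2)c2ccc(F)cc2)cc1` gives 20 mg/kg, and compound 1 `Cc1nc2ccccc2n1C1CCN(CCCC(c2ccc(F)cc2)c2ccc(F)cc2)CC1` gives 40 mg/kg. The step of a 3.1-fold lower number from compound 1 to compound 3 (0.49 log units; beyond the scatter) came with methylsulfanyl in place of methyl on an aromatic carbon, while the step of a 2.0-fold lower number from compound 1 to compound 2 (0.30 log units; within the scatter) stayed within the scatter.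

Compound 4 `OCCSc1nc2ccccc2n1C1CCN(CCCC(c2ccc(F)cc2)c2ccc(F)cc2)CC1` differs from compound 3 by hydroxymethyl in place of hydrogen on a saturated chain carbon bound to a sulfur. Among the compounds with values here, no measured step touches this chain; the nearest, methyl to methylsulfanyl in a 3.1-fold lower number from compound 1 to compound 3 (0.49 log units; beyond the scatter), shows a modest move. For compound 4 the step of a 1.2-fold higher number from compound 3 to compound 4 (0.06 log units; within the scatter) is expected to stay within the scatter, and compound 4 is estimated at 15 mg/kg, between 7 mg/kg and 35 mg/kg.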

Compound 4, dose for half-maximal effect: 40 mg/kg
Estimate against measurement, compound 4: 2.7-fold (0.43 log units) below; measured number outside the range, above it.
By their numbers in this assay, from the lowest: compounds 3, 2, 1 and 4 (each within the scatter of the next, the first and the last beyond it).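

Within the data shown here, the chain on sulfur is not a neutral place to add atoms: hydroxymethyl in place of hydrogen gives a 3.1-fold higher number from compound 3 to compound 4 (0.49 log units; beyond the scatter), the only measured change on this chain. The advantage of methylsulfanyl is lost with (2-hydroxyethyl)sulfanyl, which gives no change at the digits printed from compound 1 to compound 4 (within the scatter). Nothing measured here gives a reason for this rise.

Still open, as far as these compounds go, is whether the rise follows from the added chain length or from the hydroxyl group itself. An ethylsulfanyl or propylsulfanyl group would help separate the two, and a (2-aminoethyl)sulfanyl group would test another end group on the same chain.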